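This account rests on a few compounds, and the source may have more. Where it says the series, first, only, none or still open, it means among the compounds named here.

Measured so far:
compound 1 `COC(=O)C1=C(C)NC(=O)NC1c1cccs1` — in an assay on membranes from CHO cells for displacement of a labelled ligand from adenosine receptor A1 (Homo sapiens), read by scintillation counting, with a stated time of 60 min, tested at 1 uM (a lower number here means less inhibition, a higher number more inhibition at the concentration tested (going by the name of the read-out)), compound 1 gives 6%
compound 2 `CCNC(=O)C1=C(C)NC(=O)NC1c1ccco1` — in this assay compound 2 gives 2%

Compound 2 holds the lower of the two numbers, and compound 1 sits within the scatter of it, so the two cannot be told apart. Compound 3 `CCNC(=O)C1=C(C)NC(=O)NC1c1cccs1` is not yet measured. It differs from compound 2 by thiophen-2-yl in place of furan-2-yl on a saturated ring carbon. No measured pair isolates this change, so nothing shown speaks for a shift in either direction; the expected step is none beyond the scatter, and a number 3 percentage points higher from compound 2 to compound 3 (within the scatter) is the estimate. Compound 3 is therefore expected to give 5%, with a range from -5% to 16%.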

Compound 3, a percentage reported as inhibition, at one concentration (the size of the read-out at that concentration, not a potency): 1%
Estimate against measurement, compound 3: 4 percentage points above, within the range that was stated.
By their numbers in this assay, from the lowest: compounds 3, 2 and 1 (each within the scatter of the next).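

In this assay, among these compounds, thiophen-2-yl in place of furan-2-yl on a saturated ring carbon gives a number 1 percentage points lower from compound 2 to compound 3 (within the scatter), the first matched comparison at this position, and it does not separate the two rings. Ethylamino in place of methoxy on a carbonyl carbon gives a number 5 percentage points lower from compound 1 to compound 3 (within the scatter), so that change does not separate the compounds either. No data on hand bear on the reason for these results.

On these data alone, whether any group at either place can move this read-out stays open. A phenyl ring on the saturated ring carbon, or a longer chain in place of ethylamino, would test this.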